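This account rests on a few compounds, and the source may have more. Where it says the series, first, only, none or still open, it means among the compounds named here.

The measured compounds in an ADME assay on BHK-21 cells (Mesocricetus auratus) for cytotoxicity, read by MTT assay, with a stated time of 72 h; a higher number here means that more compound is tolerated, a lower number that less compound is tolerated:
- compound 1 `NS(=O)(=O)c1ccc(N2N=C(c3ccc(OCc4ccccc4)cc3)CC2c2ccc(F)cc2)cc1` gives 60000 nM
- compound 2 `NS(=O)(=O)c1ccc(N2N=C(c3ccc(Oc4ccccc4)cc3)CC2c2ccc(F)cc2)cc1` gives 8000 nM
- compound 3 `NS(=O)(=O)c1ccc(N2N=C(c3ccc(Oc4ccccc4)cc3)CC2c2cccc(Cl)c2)cc1` gives 9000 nM

Compound 1 stands highest of these three numbers, so it is the best tolerated of the set. Within the data shown here, the one change that clearly mattered was a 7.5-fold lower number from compound 1 to compound 2 (0.88 log units; beyond the scatter), a change away from the saturated ring. In contrast, a 1.1-fold higher number from compound 2 to compound 3 (0.05 log units; within the scatter) shows that swapping the aryl group on the saturated ring carbon left the read-out essentially where it was.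

Compound 4 `Cc1ccccc1C1CC(c2ccc(OCc3ccccc3)cc2)=NN1c1ccc(S(N)(=O)=O)cc1` is the unmeasured compound. Its change from compound 1 is 2-methylphenyl in place of 4-fluorophenyl on a saturated ring carbon. This is the same kind of change as the step from compound 2 to compound 3: an aryl group on the saturated ring carbon replaced by another aryl group, while the benzyl group on the oxygen, which distinguishes compound 1 from compound 2, is kept. Since that earlier swap stayed within the scatter, the expectation for compound 4 in this assay is a step of about no change at the digits printed from compound 1 to compound 4 (within the scatter), that is, none beyond the scatter. Compound 4 is therefore estimated at 60000 nM, with a range from 25000 nM to 130000 nM.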

Compound 4, half-maximal cytotoxic concentration: 20000 nM
Beside the measured number, compound 4's estimate is 3.0-fold (0.48 log units) above it, and the stated range ends above it.
By their numbers in this assay, from the lowest: compounds 2 and 3 (each within the scatter of the next); then compound 4; then compound 1.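

In this assay the aryl group on the saturated ring carbon turns out to matter, since the number falls in (a 3.0-fold lower number from compound 1 to compound 4 (0.48 log units; beyond the scatter)) by a step beyond the scatter, whereas the earlier swap at this carbon (a 1.1-fold higher number from compound 2 to compound 3 (0.05 log units; within the scatter)) stayed within it. So the earlier result cannot be taken as a general rule that aryl swaps here make no difference, at least not where the benzyl group on the oxygen is kept. The leaving 4-fluorophenyl and the entering 2-methylphenyl have the same heavy-atom count, the same kind of ring and no hydrogen-bond donors or acceptors, so those counts do not tell these two groups apart, and nothing measured here accounts for the drop.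

Going by these compounds, the two steps at this carbon differ in both the groups exchanged and the group on the oxygen, so it remains open whether the drop comes from adding the methyl, losing the fluorine or the pairing with the benzyl group. An unsubstituted phenyl or a 4-methylphenyl on this carbon, or 2-methylphenyl with phenyl on the oxygen, would help separate these possibilities.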